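Methyl to Methoxy on a Fused Benzothiazole-Type Core

The source may report more compounds than this note shows. Statements on the series, on what has been measured and on what is new or still open speak of the compounds shown alone.

Measured compounds:
Compound 1, `O=[N+]([O-])c1ccc(-c2nnc(-c3cccnc3)n2Nc2nc3ccc(F)cc3s2)cc1`: >= 108 ug/mL in an ADME assay on MT4 cells (Homo sapiens) for cytotoxicity, read by MTT assay, with a stated time of 5 days; a lower number here means that less compound is tolerated, a higher number that more compound is tolerated
Compound 2, `Cc1ccc2nc(Nn3c(-c4ccc([N+](=O)[O-])cc4)nnc3-c3cccnc3)sc2c1`: 64.4 ug/mL in this assay

Compound 1 is reported only as a limit of this assay, namely >= 108 ug/mL. Within the data shown here, compound 2 gives 64.4 ug/mL in this assay, the only actual number in the set. The other entry, that of compound 1, is a limit, described by the limit of >= 108 ug/mL in this assay, at which 1 of the 2 values shown sits. Among the measured compounds shown here, the one measured step is an at least 1.6-fold lower number from compound 1 to compound 2 (0.22 log units; that floor lies within the scatter), a change whose floor lies within the scatter, so it does not show a clear effect of swapping one small group on an aromatic carbon for another.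

Compound 3, `COc1ccc2nc(Nn3c(-c4ccc([N+](=O)[O-])cc4)nnc3-c3cccnc3)sc2c1`, differs from compound 2 by methoxy in place of methyl on an aromatic carbon. For the measured compounds named here, the step from compound 1 to compound 2 is the only comparison that bears on this change, and it was small; the new step is likewise a small group exchanged on an aromatic carbon, so no movement beyond the scatter is expected in this assay, in either direction. Compound 3 is therefore estimated at 70 ug/mL, with a plausible range from 35 ug/mL to 140 ug/mL, meaning an expected step of a 1.1-fold higher number from compound 2 to compound 3 (0.04 log units; within the scatter).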

Compound 3, half-maximal cytotoxic concentration: 12.9 ug/mL
Estimate against measurement, compound 3: 5.4-fold (0.73 log units) above; measured number outside the range, below it.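

Exchanging methyl for methoxy on this aromatic carbon gives a 5.0-fold lower number from compound 2 to compound 3 (0.70 log units; beyond the scatter) in this assay and so shows what the earlier step could not: a swap between small groups at this position can move the number beyond the scatter. Methoxy in place of fluoro gives an at least 8.3-fold lower number from compound 1 to compound 3 (0.92 log units; beyond the scatter) in the same assay, and with both steps beyond the scatter, methoxy is the group among the three shown with which the least compound is tolerated. As far as these compounds go, compound 1 is described only by a limit, so the second step is a floor and its full size stays unknown: the limit of >= 108 ug/mL in this assay, at which 1 of the 3 values shown sits.

The compounds shown do not separate the part played by the oxygen of methoxy from that of the group as a whole, which a hydroxy or an ethyl on the same carbon would help to address. They also leave open whether an amine or a longer alkoxy chain here would lower the number further, or whether the number would return toward that seen with methyl.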